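The source may hold more compounds than are shown below. What is called first, only, known or untested is meant among the compounds shown, and "the series" means these compounds.

Measured so far in an assay for inhibition of Thromboxane-A synthase (Homo sapiens), using microsomes; on this read-out lower numbers stand for stronger inhibition and higher numbers for weaker inhibition:
compound 1 `O=C(O)CC/C=C\CC1COC(c2ccccc2Cl)OC1c1cccnc1` — 48 nM
compound 2 `N#Cc1ccccc1C1OCC(C/C=C\CCC(=O)O)C(c2cccnc2)O1` — 54 nM
compound 3 `O=C(O)CC/C=C\CC1COC(c2ccco2)OC1c1cccnc1` — 164 nM

Compound 2 gives the second highest of the three numbers; compound 1 lies within the scatter of it a 1.1-fold higher number from compound 1 to compound 2 (0.05 log units; within the scatter), and compound 3 is furthest, beyond the scatter a 3.0-fold higher number from compound 2 to compound 3 (0.48 log units; beyond the scatter).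

Compound 4 `CC(C)(Oc1ccccc1)C1OCC(C/C=C\CCC(=O)O)C(c2cccnc2)O1` is not yet measured. It differs from compound 2 at the saturated ring carbon between two ring oxygen atoms: a group of 10 heavy atoms (9 carbon, 1 oxygen; one six-membered aromatic ring of carbon only) in place of a group of 8 heavy atoms (7 carbon, 1 nitrogen; one six-membered aromatic ring of carbon only), on a saturated ring carbon.

Within the data shown here, two measured steps touch that position, a 3.4-fold higher number from compound 1 to compound 3 (0.53 log units; beyond the scatter) and a 3.0-fold higher number from compound 2 to compound 3 (0.48 log units; beyond the scatter), both modest rises in number. Among the measured compounds shown here, no measured step brings in a group of this kind, so the direction is uncertain; a modest rise is expected, a 2.0-fold higher number from compound 2 to compound 4 (0.31 log units; beyond the scatter). Compound 4 is estimated at 110 nM, range 40 nM to 300 nM.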

Compound 4, half-maximal inhibitory concentration: 52 nM
For compound 4 the middle estimate is 2.1-fold (0.33 log units) above the measured one; measured number inside the range.
By their numbers in this assay, from the lowest: compounds 1, 4 and 2 (each within the scatter of the next); then compound 3.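

In this assay the saturated ring carbon between two ring oxygen atoms accepts the group of 10 heavy atoms without a change beyond the scatter (a 1.0-fold lower number from compound 2 to compound 4 (0.02 log units; within the scatter); a 1.1-fold higher number from compound 1 to compound 4 (0.03 log units; within the scatter)). Among the compounds shown, each group with a six-membered aromatic ring of carbon only stays within the scatter of the others, while furan-2-yl stands apart (a 3.2-fold lower number from compound 3 to compound 4 (0.50 log units; beyond the scatter)). No measured evidence accounts for this result.

Still open, from the compounds shown here alone, is whether an amine or a carboxylic acid on this group would leave the number unchanged. A longer chain between the ring carbon and the aromatic ring is equally untested among these compounds.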